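The source may report more compounds than this note shows. Statements on the series, on what has been measured and on what is new or still open speak of the compounds shown alone.

Measured so far:
compound 1 `COc1cc2c(Nc3ccc(C#N)cc3)ncnc2cc1OCCCN(C)Cc1ccccc1` — > 100000 nM
compound 2 `COc1cc2c(Nc3ccc(C#N)cc3)ncnc2cc1OCCCN1CCC(C)CC1` — 32100 nM

In a functional assay on HepG2 cells (Homo sapiens) for antiproliferative activity, read by MTT assay, with a stated time of 72 h (on this read-out lower numbers stand for stronger inhibition and higher numbers for weaker inhibition), compound 1 gives only a limit of the assay, > 100000 nM, and no number (the limit of > 100000 nM in this assay, at which 1 of the 2 values shown sits). Compound 2 gives 32100 nM in this assay. Among the compounds with values here, the single measured step, an at least 3.1-fold lower number from compound 1 to compound 2 (0.49 log units; beyond the scatter), lies beyond the scatter: the 4-methylpiperidin-1-yl analogue reaches a number where the benzyl(methyl)amino analogue stays at the limit.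

Compound 3 `COc1cc2c(Nc3ccc(C#N)cc3)ncnc2cc1OCCCN1CCC(N(C)C)CC1` is not yet measured. Against compound 1 it differs by 4-(dimethylamino)piperidin-1-yl in place of benzyl(methyl)amino on a saturated chain carbon, three bonds along the chain from an oxygen on an aromatic ring. The step from compound 1 to compound 2 is the only one that bears on it, since compound 2 and compound 3 both carry a piperidin-1-yl ring at this place. A lowering of the size seen in an at least 3.1-fold lower number from compound 1 to compound 2 (0.49 log units; beyond the scatter) or somewhat more is therefore expected, though from a limit its true size cannot be fixed. Compound 3 is estimated at 25000 nM in this assay, with a range from 8000 nM to 100000 nM. That estimate means an at least 4.0-fold lower number from compound 1 to compound 3 (0.60 log units; beyond the scatter) is expected.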

Compound 3, half-maximal inhibitory concentration: 33600 nM
Estimate against measurement, compound 3: 1.3-fold (0.13 log units) below, within the range that was stated.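

In this assay, the 4-(dimethylamino)piperidin-1-yl group also gives a number in place of benzyl(methyl)amino, with an at least 2.9-fold lower number from compound 1 to compound 3 (0.47 log units; beyond the scatter), so this outcome is no longer tied to the 4-methylpiperidin-1-yl group alone. On the saturated ring carbon, dimethylamino in place of methyl gives a 1.0-fold higher number from compound 2 to compound 3 (0.02 log units; within the scatter), so these two groups cannot be told apart in this assay. The size of the step away from benzyl(methyl)amino stays unfixed because compound 1 has only a limit: the limit of > 100000 nM in this assay, at which 1 of the 3 values shown sits.

On these data alone, whether an unsubstituted piperidin-1-yl, a morpholin-4-yl group or a longer chain at this place would shift the number beyond the scatter remains open. Also open, as far as these compounds go, is whether a carboxylic acid on the saturated ring carbon would separate from methyl and dimethylamino.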